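The source may report more compounds than this note shows. Statements on the series, on what has been measured and on what is new or still open speak of the compounds shown alone.

In an assay on HEK293 cells for inhibition of Toll-like receptor 8 (Homo sapiens), with a stated time of 16 h (on this read-out higher numbers stand for weaker inhibition and lower numbers for stronger inhibition), compound 3 `O=C(Nc1ccc(Oc2cc(C(F)(F)F)cc(C(F)(F)F)c2)cc1)c1cc(Cl)ccc1F` gives 1110 nM, the lowest of the two numbers recorded, and compound 2 `O=C(Nc1ccc(Oc2cc(C(F)(F)F)cc(C(F)(F)F)c2)cc1)c1ccccc1F` gives 3000 nM. Compound 1 `Fc1cccc(Cl)c1CNc1ccc(Oc2cc(C(F)(F)F)cc(C(F)(F)F)c2)cc1` reaches only a limit of this assay, > 50000 nM, namely (the limit of > 50000 nM in this assay, at which 1 of the 3 values shown sits). The measured steps that bear on changes to this aryl group are large or modest: an at least 16-fold lower number from compound 1 to compound 2 (1.22 log units; beyond the scatter), an at least 45-fold lower number from compound 1 to compound 3 (1.65 log units; beyond the scatter), and a 2.7-fold lower number from compound 2 to compound 3 (0.43 log units; beyond the scatter). Compound 4 `O=C(Nc1ccc(Oc2cc(C(F)(F)F)cc(C(F)(F)F)c2)cc1)c1c(F)cccc1Br` differs from compound 3 in one place: 2-bromo-6-fluorophenyl in place of 5-chloro-2-fluorophenyl on a carbonyl carbon. Since the chloro present in compound 3 gave a 2.7-fold lower number from compound 2 to compound 3 (0.43 log units; beyond the scatter) and is absent in compound 4, a modest rise in number is expected, with the bromo an open question. Compound 4 is therefore estimated at 2500 nM, between 600 nM and 10000 nM, an expected step of a 2.3-fold higher number from compound 3 to compound 4 (0.35 log units; beyond the scatter).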

Compound 4, half-maximal inhibitory concentration: 6000 nM
The estimate for compound 4 lay 2.4-fold (0.38 log units) below the measured number; the range from low to high includes it.
By their numbers in this assay, from the lowest: compound 3; then compounds 2 and 4 (each within the scatter of the next). At a limit, above all of these: compound 1.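

In this assay, the 2-bromo-6-fluorophenyl group in place of the 5-chloro-2-fluorophenyl group on the carbonyl carbon gives a 5.4-fold higher number from compound 3 to compound 4 (0.73 log units; beyond the scatter). The added bromo gives a 2.0-fold higher number from compound 2 to compound 4 (0.30 log units; within the scatter), so this halogen does not repeat the step seen with chloro. Compound 1 stands at a limit of the assay, and the step to the bromo amide reads an at least 8.3-fold lower number from compound 1 to compound 4 (0.92 log units; beyond the scatter).

As far as these compounds go, whether the kind of halogen or its place on the ring sets the gap stays open, as both change together. From the compounds shown here alone, how a methoxy group or an amine on this ring would read also remains open.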